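Chloro for Fluoro on the Aryl Amine of Compound 3

The source may hold more compounds than are shown below. What is called first, only, known or untested is meant among the compounds shown, and "the series" means these compounds.

Among the three compounds measured in a functional assay on PC-3 cells (Homo sapiens) for cytotoxicity, read by MTT assay, with a stated time of 72 h (on this read-out lower numbers stand for stronger inhibition and higher numbers for weaker inhibition), compound 3 `COc1ccc(S(=O)(=O)c2nc3ccccc3nc2Nc2ccc(F)cc2)cc1` stands lowest, giving 2200 nM. Compound 1 `COc1ccc(Nc2nc3ccccc3nc2S(=O)(=O)c2ccc(OC)cc2)cc1` gives 8710 nM and compound 2 `COc1ccc(S(=O)(=O)c2nc3ccccc3nc2Nc2cccc(N)c2)cc1` gives 8600 nM; the two differ by a 1.0-fold lower number from compound 1 to compound 2 (0.01 log units; within the scatter), whereas the moves to compound 3 are larger, a 4.0-fold lower number from compound 1 to compound 3 (0.60 log units; beyond the scatter) and a 3.9-fold lower number from compound 2 to compound 3 (0.59 log units; beyond the scatter). Compound 4 `COc1ccc(S(=O)(=O)c2nc3ccccc3nc2Nc2ccc(Cl)cc2)cc1` is the next step: chloro in place of fluoro on an aromatic carbon. For the measured compounds named here, no measured step swaps one halogen for another; the only step touching that position is a 4.0-fold lower number from compound 1 to compound 3 (0.60 log units; beyond the scatter), which exchanged a methoxy for a fluoro and so does not speak directly to a chloro. With nothing in the series pointing either way, the change is expected to stay within the scatter, perhaps nudging slightly lower. Compound 4 is therefore estimated at 1800 nM, with a range from 600 nM to 5000 nM. The expected step from compound 3 to compound 4 is a 1.2-fold lower number from compound 3 to compound 4 (0.09 log units; within the scatter).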

Compound 4, half-maximal inhibitory concentration: 31800 nM
For compound 4 the middle estimate is 18-fold (1.25 log units) below the measured one; the measured number lies above the stated range.
By their numbers in this assay, from the lowest: compound 3; then compounds 2 and 1 (each within the scatter of the next); then compound 4.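

In this assay, for the compounds shown here, this position proves far more sensitive than the earlier compounds could show: exchanging one halogen for another on the aromatic carbon para to a large group gives a 14-fold higher number from compound 3 to compound 4 (1.16 log units; beyond the scatter) even though one heavy atom replaces one heavy atom and no hydrogen-bond donor or acceptor enters or leaves. The chloro also puts compound 4 behind both other compounds, with a 3.7-fold higher number from compound 2 to compound 4 (0.57 log units; beyond the scatter) and a 3.7-fold higher number from compound 1 to compound 4 (0.56 log units; beyond the scatter), so the 4-fluorophenyl and 4-chlorophenyl compounds mark the two ends of the series. No available evidence bears on why this exchange produces so large a step.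

The compounds shown leave open how a bromo, a methyl or a trifluoromethyl group would read at this place. They also leave open whether the same exchange would give a step of similar size with a different group elsewhere on the shared core.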